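The compounds below may be only part of what the source reports. "The series", "measured", "known", "first", "only" and "open" are said of these compounds alone.

Three close relatives of a cinnamate ester, each carrying two nitrate-bearing chains, were tested in a functional assay on NCI-H1792 cells (Homo sapiens) for cytotoxicity, read by resazurin assay, with a stated time of 72 h; a higher number here means a weaker inhibitor, a lower number a stronger inhibitor. Compound 1 `O=C(/C=C/c1ccc(OCCCCCO[N+](=O)[O-])c(O)c1)OCCCCCO[N+](=O)[O-]` gives > 50000 nM, which is a limit of the assay and not a number. Compound 3 `COc1cc(/C=C/C(=O)OCCCCCO[N+](=O)[O-])ccc1OCCCCCO[N+](=O)[O-]` carries methyl in place of hydrogen on an oxygen on an aromatic ring and likewise gives only a limit of > 50000 nM. The step that the two limits leave unreadable from compound 1 to compound 3 therefore cannot be read, since (the limit of > 50000 nM in this assay, at which 3 of the 3 values shown sit). Compound 2 `O=C(/C=C/c1ccc(OCCCCO[N+](=O)[O-])c(O)c1)OCCCCO[N+](=O)[O-]` also returns only a limit of > 50000 nM in this assay. How the cores of compound 1 and compound 2 differ is not broken down here. Compound 4 `COc1cc(/C=C/C(=O)OCCCCO[N+](=O)[O-])ccc1OCCCCO[N+](=O)[O-]` is not yet measured; it differs from compound 2 by methyl in place of hydrogen on an oxygen on an aromatic ring, the same change as from compound 1 to compound 3. The step that the limit leaves unreadable from compound 2 to compound 4 is expected to be small, resting on compound 1 and compound 3 sitting together at the limit of > 50000 nM in this assay, at which 3 of the 3 values shown sit. Compound 4 is expected to give about 80000 nM, most likely between 40000 nM and 200000 nM.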

Compound 4, half-maximal inhibitory concentration: > 50000 nM
Compound 4: only a limit was reported; the forecaster's own chance of this, stated with the estimate: 85%; the middle value is on the limit's open side.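

Among the compounds shown here, compound 2 and compound 4 each return only a limit in this assay, so no step between them can be read: the limit of > 50000 nM in this assay, at which 4 of the 4 values shown sit. The compounds shown leave open whether hydroxy to methoxy changes cytotoxicity at all in this assay on any of these cores.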